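This account rests on a few compounds, and the source may have more. Where it says the series, first, only, none or still open, it means among the compounds named here.

Measured compounds in an assay on CHO cells for antagonist activity at transient receptor potential cation channel subfamily V member 1 (Homo sapiens), read by FLIPR; a higher number here means a weaker inhibitor, a lower number a stronger inhibitor:
Compound 1 `CC1CCN(c2cc(C(F)(F)F)ccc2CNC(=O)C(C)c2ccc(NS(C)(=O)=O)c(F)c2)CC1` gives 0.9 nM.
Compound 2 `CC(C(=O)NCc1ccc(C(F)(F)F)cc1OC1CCCC1)c1ccc(NS(C)(=O)=O)c(F)c1` gives 0.6 nM.
Compound 3 `CC(C(=O)NCc1ccc(C(F)(F)F)cc1SC1CCCC1)c1ccc(NS(C)(=O)=O)c(F)c1` gives 0.3 nM.

Compound 3 has the lowest number of the three. Its nearest neighbour is compound 2, and the step of a 2.0-fold lower number from compound 2 to compound 3 (0.30 log units; within the scatter) stays within the scatter, so these two cannot be ranked against each other. The step of a 3.0-fold lower number from compound 1 to compound 3 (0.48 log units; beyond the scatter) lies beyond the scatter, so compound 3 does separate from compound 1, though only modestly.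

Compound 4 `CC(C(=O)NCc1ccc(C(F)(F)F)cc1SCc1ccccc1)c1ccc(NS(C)(=O)=O)c(F)c1` has not yet been measured. It differs from compound 3 in one place: benzyl in place of cyclopentyl on a sulfur. Among the compounds with values here, none of the measured steps changes the group carried on the sulfur. The steps of a 1.5-fold lower number from compound 1 to compound 2 (0.18 log units; within the scatter) and a 3.0-fold lower number from compound 1 to compound 3 (0.48 log units; beyond the scatter) exchange the whole group on the aromatic carbon, and a 2.0-fold lower number from compound 2 to compound 3 (0.30 log units; within the scatter) keeps cyclopentyl throughout. All three steps are modest, and the three measured compounds sit within a narrow band, which gives no basis for expecting a large move in either direction. The expectation for compound 4 is therefore a step of a 1.3-fold higher number from compound 3 to compound 4 (0.12 log units; within the scatter) that stays within the scatter. In this assay compound 4 is estimated at 0.4 nM, with a range from 0.15 nM to 1.2 nM.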

Compound 4, inhibition constant: 0.5 nM
Estimate against measurement, compound 4: 1.3-fold (0.10 log units) below; measured number inside the range.
By their numbers in this assay, from the lowest: compounds 3, 4, 2 and 1 (each within the scatter of the next, the first and the last beyond it).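

In this assay, within the data shown here, the step of a 1.7-fold higher number from compound 3 to compound 4 (0.22 log units; within the scatter) is the first measured change to the group on the sulfur, and it replaces a five-membered non-aromatic ring with benzyl, which carries a six-membered aromatic ring, without a change that can be told from the scatter. Compound 4 also cannot be ranked against the two compounds without sulfur, as the steps of a 1.2-fold lower number from compound 2 to compound 4 (0.08 log units; within the scatter) and a 1.8-fold lower number from compound 1 to compound 4 (0.26 log units; within the scatter) both stay within the scatter, so the separation seen in the step of a 3.0-fold lower number from compound 1 to compound 3 (0.48 log units; beyond the scatter) does not carry over to the benzylsulfanyl compound, although compound 3 and compound 4 themselves cannot be told apart. Nothing measured here accounts for this result.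

The compounds shown leave open whether an amine or a carboxylic acid on the group held by the sulfur, or a longer chain such as phenylethyl, would stay in this same narrow band. They also leave open whether benzyloxy, with oxygen in place of the sulfur, would match benzylsulfanyl as closely as cyclopentyloxy matches cyclopentylsulfanyl.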